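The compounds below may be only part of what the source reports. "The series", "measured", "known", "first", "only" and "open" are said of these compounds alone.

Measured so far:
- compound 1, `CC(C)C[C@@H](N)C(=O)Nc1cc2cc[nH]c(=O)c2cc1Cl`: 19 nM
- compound 2, `CC(C)(C)C[C@H](N)C(=O)Nc1cc2cc[nH]c(=O)c2cc1Cl`: 845 nM
- compound 3, `CN(C)[C@H]1CC[C@@H](C(=O)Nc2cc3cc[nH]c(=O)c3cc2Cl)CC1`: 1000 nM

In an assay on isolated protein for inhibition of Rho-associated protein kinase 2 (Homo sapiens) (a lower number here means a stronger inhibitor, a higher number a weaker inhibitor), compound 2 gives 845 nM, the second highest of the three numbers; its value and that of compound 3 lie within the scatter of each other, while compound 1 sits far lower. The unmeasured compound 4, `O=C(Nc1cc2cc[nH]c(=O)c2cc1Cl)[C@H]1CCCN1`, differs from compound 2 by a single change: pyrrolidin-2-yl in place of 1-amino-3,3-dimethylbutyl on a carbonyl carbon. Going by the values given here, only one measured step bears on this position. That step, a 44-fold higher number from compound 1 to compound 2 (1.65 log units; beyond the scatter), shows that reshaping the group on the carbonyl carbon of the shared core can move the number a great deal. Compound 4 reverses part of that: the bulkier chain leaves and a small ring with its nitrogen enters. Among the compounds with values here, a step back towards the lower number of compound 1 is therefore expected for compound 4, though with wide uncertainty, since no measured pair shows this ring directly. Compound 4 is estimated at 200 nM (range 40 nM to 1500 nM), meaning an expected step of a 4.2-fold lower number from compound 2 to compound 4 (0.63 log units; beyond the scatter).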

Compound 4, half-maximal inhibitory concentration: 130 nM
The estimate for compound 4 lay 1.5-fold (0.19 log units) above the measured number, within the range that was stated.
By their numbers in this assay, from the lowest: compound 1; then compound 4; then compounds 2 and 3 (each within the scatter of the next).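

The steps at this position so far had shown only what a change in a chain can do, and in this assay pyrrolidin-2-yl in place of 1-amino-3,3-dimethylbutyl gives a 6.5-fold lower number from compound 2 to compound 4 (0.81 log units; beyond the scatter), so a five-membered ring with its nitrogen can work better here than the bulkier chain. The ring does not match the smaller chain, however: pyrrolidin-2-yl in place of 1-amino-3-methylbutyl gives a 6.8-fold higher number from compound 1 to compound 4 (0.84 log units; beyond the scatter), so the choice of group on this carbonyl carbon still matters after the switch to a ring. Nothing available here explains either step.

Going by these compounds, it remains open whether the ring or its nitrogen matters more, a question that cyclopentyl, which has no nitrogen, could help to answer. A six-membered piperidin-2-yl could show whether a larger ring fits this position as well, and the mirror-image pyrrolidin-2-yl could test the role of the stereocentre.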